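A few compounds are considered here, and "the series" means these few. Any claim that something is new, unique, unknown or untested is made for them only; others in the source may bear on it.

Among the measured compounds shown here, in a physicochemical assay for lipophilicity, measured as octanol-water partition (a lower number here means a more polar compound, a higher number a more lipophilic compound), compound 2 (`O=C(COc1cccc2ccccc12)N/N=C/c1ccccc1O`) stands at 3.73, the lower of the two numbers so far, with compound 1 (`O=C(COc1cccc2ccccc12)N/N=C/c1ccc(Br)cc1`) at 4.81. Compound 3 (`CSc1ccc(/C=N/NC(=O)COc2cccc3ccccc23)cc1`) differs from compound 2 on the carbon with a double bond to nitrogen: 4-(methylsulfanyl)phenyl in place of 2-hydroxyphenyl on a carbon with a double bond to nitrogen. For the measured compounds named here, one measured step bears on this change: a number 1.08 log units lower from compound 1 to compound 2 (beyond the scatter), where 2-hydroxyphenyl took the place of 4-bromophenyl. Here 2-hydroxyphenyl leaves instead, so a large move in the opposite direction is expected, and the estimate is a number 0.87 log units higher from compound 2 to compound 3 (beyond the scatter). For compound 3 the expected value is 4.6, with an estimated range from 4.2 to 5.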

Compound 3, partition coefficient: 4.11
Compound 3: the middle estimate sits 0.49 log units above what was measured; the whole stated range lies above it.
By their numbers in this assay, from the lowest: compound 2; then compound 3; then compound 1.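

Replacing 2-hydroxyphenyl with 4-(methylsulfanyl)phenyl on the carbon with a double bond to nitrogen gives a number 0.38 log units higher from compound 2 to compound 3 (beyond the scatter) in this assay. Losing 2-hydroxyphenyl therefore does not lead to one fixed number, as the group that enters also counts: methylsulfanyl in place of bromo on an aromatic carbon gives a number 0.70 log units lower from compound 1 to compound 3 (beyond the scatter). Nothing measured here explains the gap between these two groups. The compounds shown leave open where a plain phenyl would fall, and how an amine or a carboxylic acid would read in place of methylsulfanyl on that aromatic carbon.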